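Compound 2 to compound 3: cyclohexyl out, methyl in

The compounds below may be only part of what the source reports. "The series", "measured", "known", "first", "only" and "open" are said of these compounds alone.

Among the compounds with values here, in a functional assay (strain AB) with Danio rerio as the target, read by microscopy, with a stated time of 1 h (a lower number here means that less compound is needed, a higher number that more compound is needed for the effect), compound 2 `C[N+]1(CC2CCCCC2)CCc2c(sc(NC(=O)Nc3ccc(Cl)cc3)c2C(N)=O)C1` gives 100 nM as the only actual number so far. In this assay compound 1 `CCN1CCc2c(sc(NC=O)c2C(N)=O)C1` gives > 25000 nM as a limit of the assay and not a number. Compound 3 `CC[N+]1(C)CCc2c(sc(NC(=O)Nc3ccc(Cl)cc3)c2C(N)=O)C1` keeps the shared core and changes in one place: methyl in place of cyclohexyl on a saturated chain carbon bound to an amine nitrogen in a ring. Cut one bond further out, the same difference reads cyclohexylmethyl to ethyl. Within the data shown here, no measured step shows what this change does, so the expectation is only a rough one. With compound 2 at 100 nM as the sole anchor, a shift beyond the scatter is expected in this assay towards a higher number. The estimated size of the change is a 10-fold higher number from compound 2 to compound 3 (1.00 log units; beyond the scatter) on this basis. For compound 3 the estimated value is 1000 nM with an expected range from 150 nM to 8000 nM as its bounds.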

Compound 3, half-maximal effective concentration: 1960 nM
For compound 3 the middle estimate is 2.0-fold (0.29 log units) below the measured one, within the range that was stated.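

In this assay, within the data shown here, methyl in place of cyclohexyl on a saturated chain carbon bound to an amine nitrogen in a ring gives a 20-fold higher number from compound 2 to compound 3 (1.29 log units; beyond the scatter), the first measured step at this place. The result shows that this place responds strongly to the change from cyclohexylmethyl to ethyl, yet the ring is not needed for a measurable effect: compound 3 still gives 1960 nM. Compound 1 carries a limit of the assay and not a number, so no step to it can be read: the limit of > 25000 nM in this assay, at which 1 of the 3 values shown sits.

One step cannot separate the loss of the ring from the loss of chain length at this place. On these data alone, a longer open chain such as n-hexyl, or a benzyl group, would bear on that question, and the trend across intermediate sizes remains open.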